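Amide in place of urea: a small binding series

A few compounds are considered here, and "the series" means these few. Any claim that something is new, unique, unknown or untested is made for them only; others in the source may bear on it.

Measured so far:
compound 1 `COc1ccc(-n2cc3nc(C)nc(NC(=O)Nc4ccccc4)c3n2)cc1` gives 5%
compound 2 `Cc1nc(NC(=O)Nc2ccccc2)c2nn(-c3ccccc3)cc2n1` gives 1%

In an assay on CHO cells for displacement of a labelled ligand from adenosine receptor A1 (Homo sapiens), read by scintillation counting, with a stated time of 120 min, tested at 1 uM (on this read-out higher numbers stand for more inhibition at the one concentration tested (going by the name of the read-out) and lower numbers for less inhibition), compound 2 holds the lower of the two numbers, but the step of a number 4 percentage points lower from compound 1 to compound 2 (within the scatter) lies within the scatter, so the two compounds cannot be ordered. Compound 3 `Cc1nc(NC(=O)c2cccnc2)c2nn(-c3ccccc3)cc2n1` differs from compound 2 by pyridin-3-yl in place of anilino on a carbonyl carbon. For the measured compounds named here, no measured step concerns a change on the carbonyl carbon; the only step known, a number 4 percentage points lower from compound 1 to compound 2 (within the scatter), concerns hydrogen in place of methoxy on an aromatic carbon and was itself within the scatter. Nothing here supports a shift beyond the scatter. Compound 3 is therefore expected to give 5%, in the range -8% to 22%. The step of a number 4 percentage points higher from compound 2 to compound 3 (within the scatter) is expected to stay within the scatter.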

Compound 3, a percentage reported as inhibition, at one concentration (the size of the read-out at that concentration, not a potency): 12%
For compound 3 the middle estimate is 7 percentage points below the measured one; the measured number falls inside the stated range.
By their numbers in this assay, from the lowest: compounds 2, 1 and 3 (each within the scatter of the next, the first and the last beyond it).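

In this assay, for the compounds shown here, the carbonyl carbon gives the first step beyond the scatter: pyridin-3-yl in place of anilino gives a number 11 percentage points higher from compound 2 to compound 3 (beyond the scatter). This one change removes the hydrogen-bond donor of anilino and brings in the hydrogen-bond acceptor of pyridin-3-yl, and the step cannot separate the two. No measurement available here accounts for the step. Open, going by these compounds, is how phenyl on the carbonyl carbon would read, as it would keep the amide without the pyridine nitrogen. Also open, on these data alone, is whether pyridin-3-ylamino would place the same ring on the urea.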